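The compounds below may be only part of what the source reports. "The series", "measured", "known", "first", "only" and "open" are said of these compounds alone.

Measured so far, in a functional assay on A375P cells (Homo sapiens) for antiproliferative activity, read by MTT assay, with a stated time of 48 h; a lower number here means a stronger inhibitor, a higher number a weaker inhibitor:

Compound 1 `COc1ccc(C(=O)Nc2cccc(-c3ccnc4c(N)cccc34)c2)cc1OC` gives 9500 nM.
Compound 2 `Nc1cccc2c(-c3cccc(NC(=O)c4ccc(Cl)cc4C(F)(F)F)c3)ccnc12` gives only the limit > 20000 nM.
Compound 3 `Nc1cccc2c(-c3cccc(NC(=O)c4ccc(C(F)(F)F)cc4C(F)(F)F)c3)ccnc12` gives only the limit > 20000 nM.

Compound 3 therefore stands at the limit of this assay, with no number of its own. Compound 2 sits at the same limit, as the limit of > 20000 nM in this assay, at which 2 of the 3 values shown sit, shows. Among the measured compounds shown here, the single one-place step measured, a step that the two limits leave unreadable from compound 2 to compound 3, runs between two limits, so its size cannot be read. Compound 4 `CC(=O)Nc1cccc2c(-c3cccc(NC(=O)c4ccc(C(F)(F)F)cc4C(F)(F)F)c3)ccnc12` differs from compound 3 by acetyl in place of hydrogen on a nitrogen on an aromatic ring. For the measured compounds named here, no measured step bears on this change; compound 1 only shows that the shared core can reach a number with another amide. Compound 4 is expected to stay near the limit, with an estimate of 25000 nM, range 8000 nM to 80000 nM, a step that the limit leaves unreadable from compound 3 to compound 4 expected within the scatter.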

Compound 4, half-maximal inhibitory concentration: 10100 nM
Beside the measured number, compound 4's estimate is 2.5-fold (0.39 log units) above it; the range from low to high includes it.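

In this assay, acetyl in place of hydrogen on a nitrogen on an aromatic ring gives an at least 1.9-fold lower number from compound 3 to compound 4 (0.29 log units; that floor lies within the scatter). Among the compounds shown here, this is the first one-place change with a readable bound, and compound 4 has a number where compound 3 has only a limit. The step remains a floor, and its true size cannot be read: the limit of > 20000 nM in this assay, at which 2 of the 4 values shown sit.

Open, as far as these compounds go, is whether acetyl itself matters at this nitrogen, or whether a longer acyl chain, a methanesulfonyl group or a methyl group would read the same. Also open, from the compounds shown here alone, is how this change reads with the amide of compound 1.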